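The source may report more compounds than this note shows. Statements on the series, on what has been measured and on what is new or still open speak of the compounds shown alone.

Of the compounds shown here, three built on one shared core have been tested in an ADME assay on Vero cells (Chlorocebus sabaeus) for cytotoxicity, with a stated time of 3 days; on this read-out lower numbers stand for stronger inhibition and higher numbers for weaker inhibition. Compound 1 `CCOC(=O)Nc1cc(NC(=O)c2ccccc2)c2[nH]c(-c3ccc(Br)cc3)nc2c1` carries a bromo group on an aromatic carbon. In this assay compound 1 gives > 200 ug/mL, which is a limit of the assay rather than a number. Compound 2 `CCOC(=O)Nc1cc(NC(=O)c2ccccc2)c2[nH]c(-c3ccc(C(=O)OC)cc3)nc2c1` in this assay gives 650 ug/mL. The change between them, a step that the limit leaves unreadable from compound 1 to compound 2, cannot be sized. Compound 3 `CCOC(=O)Nc1cc(NC(=O)c2ccc(F)cc2)c2[nH]c(-c3ccco3)nc2c1` in this assay gives > 200 ug/mL, again a limit and not a number. Compound 3 thus sits at the limit where, as the limit of > 200 ug/mL in this assay, at which 2 of the 3 values shown sit, records, most of the known values sit, and nothing more precise is known about it.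

Compound 4 `CCOC(=O)Nc1cc(NC(=O)c2ccccc2)c2[nH]c(-c3ccco3)nc2c1` differs from compound 3 in one place: hydrogen in place of fluoro on an aromatic carbon. For the measured compounds named here, no measured step touches this kind of change; the only measured step concerns a different group on a different ring, and its size is hidden behind a limit. There is thus no ground for expecting a step beyond the scatter in this assay, and the most likely outcome is another limit. Compound 4 is estimated at 300 ug/mL, with a range from 150 ug/mL to 700 ug/mL, which means an expected step that the limit leaves unreadable from compound 3 to compound 4.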

Compound 4, half-maximal inhibitory concentration: > 200 ug/mL
Compound 4: only a limit was reported; the forecaster's own chance of this, stated with the estimate: 70%; the middle value is on the limit's open side.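

In this assay compound 4 gives > 200 ug/mL, a limit and not a number. No step from compound 1, compound 2 or compound 3 to compound 4 can be read, and the result stands with the others: the limit of > 200 ug/mL in this assay, at which 3 of the 4 values shown sit.

The compounds shown leave open what the true values of compound 1, compound 3 and compound 4 are, and whether hydrogen in place of fluoro changes anything.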